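Indole vinyl sulfones: removing the core methoxy

The source may report more compounds than this note shows. Statements on the series, on what has been measured and on what is new or still open speak of the compounds shown alone.

Measured compounds:
compound 1 `COc1ccc(-c2[nH]c3ccccc3c2/C=C(\C#N)S(=O)(=O)c2ccccc2)cc1` — 871 nM
compound 2 `CC(=O)/C(=C\c1c(-c2ccccc2)[nH]c2ccccc12)S(=O)(=O)c1ccccc1` — 1600 nM
compound 3 `COc1ccc2[nH]c(-c3ccccc3)c(/C=C(\C#N)S(=O)(=O)c3ccccc3)c2c1` — 4700 nM

In a functional assay on MOLT-4 cells (Homo sapiens) for inhibition, read by sulforhodamine B assay, with a stated time of 48 h (a higher number here means a weaker inhibitor of growth, a lower number a stronger inhibitor of growth), compound 3 gives the highest number of the three, and its gaps to compound 2 and to compound 1 both lie beyond the scatter. Compound 4 `N#C/C(=C\c1c(-c2ccccc2)[nH]c2ccccc12)S(=O)(=O)c1ccccc1` differs from compound 3 in one place: hydrogen in place of methoxy on an aromatic carbon. For the measured compounds named here, no pair of measured compounds separated by a single change is available, so the size of this step rests on judgment. Since the methoxy on the core goes with the weakest growth inhibition shown, its removal is expected to lower the number somewhat, a 3.1-fold lower number from compound 3 to compound 4 (0.50 log units; beyond the scatter), though a result within the scatter would not surprise. For compound 4 the expected value in this assay is 1500 nM, with a range from 500 nM to 4500 nM.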

Compound 4, concentration for 50% growth inhibition: 2200 nM
Compound 4: the middle estimate sits 1.5-fold (0.17 log units) below what was measured, and the stated range covers the measured number.
By their numbers in this assay, from the lowest: compounds 1, 2 and 4 (each within the scatter of the next, the first and the last beyond it); then compound 3.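

In this assay, hydrogen in place of methoxy on the core gives a 2.1-fold lower number from compound 3 to compound 4 (0.33 log units; beyond the scatter) while the same exchange starting from compound 1, whose methoxy stands elsewhere, gives a 2.5-fold higher number from compound 1 to compound 4 (0.40 log units; beyond the scatter) so the direction of this exchange differs between the two methoxy placements. Cyano in place of acetyl gives a 1.4-fold higher number from compound 2 to compound 4 (0.14 log units; within the scatter) and so does not separate these two groups here. No measurement accompanying these compounds speaks to why the steps take this size. As far as these compounds go, whether an amine or a hydroxyl group at the core carbon would move the number remains open. So does the effect of a carboxylic acid in place of the cyano group.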